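Cytotoxicity in a Hydrazide Series: the Nitro Analogue

The source may report more compounds than this note shows. Statements on the series, on what has been measured and on what is new or still open speak of the compounds shown alone.

compound 1: `O=C(/C=C/c1ccc(Br)cc1)NNC(=O)c1ccc2c(c1)OCCO2`, 259000 nM
compound 2: `O=C(/C=C/c1ccccc1F)NNC(=O)c1ccc2c(c1)OCCO2`, 302000 nM

Of the two compounds tested in an ADME assay on cells (Macrophage) for cytotoxicity, read by MTT assay, with a stated time of 24 h (a higher number here means that more compound is tolerated, a lower number that less compound is tolerated), compound 2 stands at the top with 302000 nM, yet compound 1 sits within the scatter of it, the step of a 1.2-fold higher number from compound 1 to compound 2 (0.07 log units; within the scatter). Compound 3 `O=C(/C=C/c1ccccc1[N+](=O)[O-])NNC(=O)c1ccc2c(c1)OCCO2` differs from compound 2 by nitro in place of fluoro on an aromatic carbon. Among the measured compounds shown here, no measured step involves a nitro group; the only step, from the 4-bromophenyl to the 2-fluorophenyl analogue, did not exceed the scatter, so compound 3 is expected to show no change beyond the scatter, a 1.1-fold lower number from compound 2 to compound 3 (0.03 log units; within the scatter). The estimate for compound 3 is 280000 nM, between 140000 nM and 560000 nM.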

Compound 3, half-maximal cytotoxic concentration: 257000 nM
Estimate against measurement, compound 3: 1.1-fold (0.04 log units) above; measured number inside the range.
By their numbers in this assay, from the lowest: compounds 3, 1 and 2 (each within the scatter of the next).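

In this assay, nitro, with 3 heavy atoms and 2 hydrogen-bond acceptors, takes the place of fluoro on the same aromatic carbon, yet the step stays within the scatter (a 1.2-fold lower number from compound 2 to compound 3 (0.07 log units; within the scatter)). The 2-nitrophenyl and 4-bromophenyl analogues also stay within the scatter of each other (a 1.0-fold lower number from compound 1 to compound 3 (0.00 log units; within the scatter)). No evidence is available that bears on this result. The compounds shown leave open whether any group on this aromatic carbon moves the number beyond the scatter. An amine or a carboxylic acid there remains an open case.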